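The compounds below may be only part of what the source reports. "The series", "measured", "known", "first", "only" and "open" are said of these compounds alone.

Compound 1 `CCCCCCCCCCCCCCCCCCOC[C@H](COP(=O)(O)O[C@@H]1[C@H](O)[C@@H](CO)[C@@H](O)[C@H](O)[C@@H]1O)OC`: 2000 nM
Compound 2 `CCCCCCCCCCCCCCCCCCOC[C@H](COC(=O)O[C@@H]1[C@H](O)[C@@H](CO)[C@@H](O)[C@H](O)[C@@H]1O)OC`: 10000 nM
Compound 3 `CCCCCCCCCCCCCCCCCCOC[C@H](COP(=O)(O)O[C@@H]1[C@H](O)[C@H](CO)[C@@H](O)[C@H](O)[C@@H]1O)OC`: 4000 nM

All three values come from a functional assay on PC-3 cells (Homo sapiens) for inhibition; on this read-out higher numbers stand for weaker inhibition and lower numbers for stronger inhibition. Among the measured compounds, compound 2 has the highest number, at 10000 nM. Compound 4 `CCCCCCCCCCCCCCCCCCOC[C@H](COC(=O)O[C@@H]1[C@H](O)[C@H](CO)[C@@H](O)[C@H](O)[C@@H]1O)OC` is still unmeasured in this assay. Its relation to compound 2 is the two compounds have the same atoms and bonds and differ only in configuration as drawn: 1 of 7 stereo elements differ; a stereocentre at a saturated ring carbon is drawn S in compound 2 and R in compound 4. Among the measured compounds shown here, the one measured step with the same kind of change in configuration is a 2.0-fold higher number from compound 1 to compound 3 (0.30 log units; within the scatter), and it lies within the scatter. No change beyond the scatter is therefore expected in this assay, in either direction. The expected step is no change at the digits printed from compound 2 to compound 4 (within the scatter). For compound 4 the estimated value is 10000 nM, with an expected range of 5000 nM to 20000 nM.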

Compound 4, half-maximal inhibitory concentration: 2000 nM
Beside the measured number, compound 4's estimate is 5.0-fold (0.70 log units) above it; the whole stated range lies above it.
By their numbers in this assay, from the lowest: compounds 1, 4 and 3 (each within the scatter of the next); then compound 2.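

In this assay, a 5.0-fold lower number from compound 2 to compound 4 (0.70 log units; beyond the scatter), so the configuration at this saturated ring carbon can move the number beyond the scatter. The phosphate pair did not show this: a 2.0-fold higher number from compound 1 to compound 3 (0.30 log units; within the scatter). The carbonate pair ties the step to stereochemistry alone, with no group entering or leaving: the fact that compounds 2 and 4 differ only in the configuration as drawn.

As far as these compounds go, whether this configuration change has a similar effect with a carbamate linker or a longer chain remains open. The other ring stereocentres also remain untested by any comparison shown here.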